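Imine variation at the nitrile-bearing carbon: dinitrophenyl replaces aminostyryl

This account rests on a few compounds, and the source may have more. Where it says the series, first, only, none or still open, it means among the compounds named here.

Compound 3 `CN(C)c1ccc(/C=C/C=N/C2=C(C#N)C(c3ccc(Cl)cc3Cl)C3=C(CCCC3=O)N2c2ccc(S(N)(=O)=O)cc2)cc1` stands lowest of the three numbers in a functional assay on Ehrlich cells (Mus musculus) for cytotoxicity, read by trypan blue exclusion, with a stated time of 2 h, tested at 50 ug/mL (a higher number here means a stronger effect of the compound at the concentration tested, a lower number a weaker effect), giving 20%; compound 2 `CN(C)c1ccc(/C=N/C2=C(C#N)C(c3ccc(Cl)cc3Cl)C3=C(CCCC3=O)N2c2ccc(S(N)(=O)=O)cc2)cc1` gives 30%, within the scatter of it, while compound 1 `N#CC1=C(NC(=O)c2ccccc2)N(c2ccc(S(N)(=O)=O)cc2)C2=C(C(=O)CCC2)C1c1ccc(Cl)cc1Cl` gives 70%, well beyond it. The step of a number 40 percentage points lower from compound 1 to compound 2 (beyond the scatter) is the only large one; the step of a number 10 percentage points lower from compound 2 to compound 3 (within the scatter) is within the scatter. Compound 4 `N#CC1=C(/N=C/c2ccc([N+](=O)[O-])cc2[N+](=O)[O-])N(c2ccc(S(N)(=O)=O)cc2)C2=C(C(=O)CCC2)C1c1ccc(Cl)cc1Cl` differs from compound 3 as follows: 2,4-dinitrophenyl in place of 2-(4-(dimethylamino)phenyl)ethenyl on a carbon with a double bond to nitrogen. The imine is kept, so the bearing step is that between compound 2 and compound 3 rather than the large one from compound 1. A step of a number 10 percentage points higher from compound 3 to compound 4 (within the scatter) is expected, within or barely beyond the scatter. Compound 4 is therefore estimated at 30%, within 15% to 50%.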

Compound 4, a percentage reported as activity, at one concentration (the size of the read-out at that concentration, not a potency): 20%
Beside the measured number, compound 4's estimate is 10 percentage points above it, and the stated range covers the measured number.
By their numbers in this assay, from the lowest: compounds 3, 4 and 2 (each within the scatter of the next); then compound 1.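

On the carbon with a double bond to nitrogen, this assay does not separate the imine substituents: 2,4-dinitrophenyl in place of 2-(4-(dimethylamino)phenyl)ethenyl gives no change at the digits printed from compound 3 to compound 4 (within the scatter), and in place of 4-(dimethylamino)phenyl it gives a number 10 percentage points lower from compound 2 to compound 4 (within the scatter). Compound 4 extends this position beyond aryl groups carrying dimethylamino, and all three imines remain within the scatter of one another. No supporting data bear on why this change leaves the read-out within the scatter.

Still open, on these data alone, is whether a methyl group, a hydroxyphenyl or a carboxyphenyl on this imine carbon would depart from these values.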